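The source may report more compounds than this note shows. Statements on the series, on what has been measured and on what is new or still open speak of the compounds shown alone.

In an ADME assay for metabolic stability, read by HPLC, at pH 7.4 (a lower number here means that the compound disappears faster, a higher number that the compound lasts longer), compound 1 `CCCCCCCCNC(=O)Oc1ccc(Cl)cc1C(=O)Nc1cccc(Cl)c1` gives 43 h, compound 2 `CCCCCCCCCNC(=O)Oc1ccc(Cl)cc1C(=O)Nc1cccc(Cl)c1` gives 43 h and compound 3 `CCCCCCCCCCNC(=O)Oc1ccc(Cl)cc1C(=O)Nc1cccc(Cl)c1` gives 43 h, so compound 3 stands level with both. The next structure is compound 4 `CCCCCCCCCCNC(=O)Oc1ccc(Cl)cc1C(=O)Nc1ccc(Cl)cc1`: 4-chlorophenyl in place of 3-chlorophenyl on an amide-type nitrogen, with 4-chlorophenyl in place of 3-chlorophenyl on an amide-type nitrogen. All measured steps lie in the saturated chain: no change at the digits printed from compound 1 to compound 2 (within the scatter), no change at the digits printed from compound 1 to compound 3 (within the scatter) and no change at the digits printed from compound 2 to compound 3 (within the scatter). None of them tests the chlorophenyl group, so they bear on this change only indirectly and give no direction. The expected result is a 1.1-fold lower number from compound 3 to compound 4 (0.03 log units; within the scatter), with no step beyond the scatter anticipated. The estimated half-life for compound 4 is 40 h, with an expected range of 18 h to 85 h.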

Compound 4, half-life: 43 h
For compound 4 the middle estimate is 1.1-fold (0.03 log units) below the measured one, and the stated range covers the measured number.
By their numbers in this assay, from the lowest: compounds 1, 2, 3 and 4 (each within the scatter of the next).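

In this assay, 4-chlorophenyl in place of 3-chlorophenyl on an amide-type nitrogen gives no change at the digits printed from compound 3 to compound 4 (within the scatter). Among these compounds, this is the first measured step outside the saturated chain, so the half-life now proves insensitive to this one change on the aryl side as well as to the chain steps. Nothing measured here offers an explanation for this result. Open, as far as these compounds go, is whether a pyridyl or an unsubstituted phenyl on this nitrogen would also leave the half-life unchanged. Equally open, from the compounds shown here alone, is the effect of an amine or a carboxylic acid at the chain end.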